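From fluoro to a third ((4-hydroxyphenyl)carbonyl)oxy group

A few compounds are considered here, and "the series" means these few. Any claim that something is new, unique, unknown or untested is made for them only; others in the source may bear on it.

Compound 1, `O=C(Oc1ccc(Cl)cc1OC(=O)c1ccc(O)c(O)c1)c1ccc(O)c(O)c1`, in a functional assay on NCI-H1299 cells (Homo sapiens) for inhibition, read by scintillation counting, with a stated time of 30 min, tested at 30 uM; a lower number here means less inhibition, a higher number more inhibition at the concentration tested (going by the name of the read-out): 94.4%
Compound 2, `O=C(Oc1cccc(F)c1OC(=O)c1ccc(O)cc1)c1ccc(O)cc1`, in this assay: 92.6%

Among the measured compounds shown here, compound 2 has the lower of the two numbers measured so far, but its gap to compound 1 lies within the usual scatter of repeated measurements, so the two readings cannot be told apart; both sit near the top of the scale.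

Compound 3, `O=C(Oc1cccc(OC(=O)c2ccc(O)cc2)c1OC(=O)c1ccc(O)cc1)c1ccc(O)cc1`, has not been measured. It differs from compound 2 in one place: ((4-hydroxyphenyl)carbonyl)oxy in place of fluoro on an aromatic carbon. For the measured compounds named here, no step between measured compounds is available to guide the size of this change, so the expectation rests on the high level shared by compound 1 and compound 2. A step no larger than the scatter, in either direction, is expected. Compound 3 is estimated to give about 90% in this assay, with a range from 75% to 98%. This amounts to an expected step of a number 2.6 percentage points lower from compound 2 to compound 3 (within the scatter).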

Compound 3, a percentage reported as inhibition, at one concentration (the size of the read-out at that concentration, not a potency): 88.7%
Estimate against measurement, compound 3: 1.3 percentage points above; the measured number falls inside the stated range.
By their numbers in this assay, from the lowest: compounds 3, 2 and 1 (each within the scatter of the next).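

Putting ((4-hydroxyphenyl)carbonyl)oxy in place of fluoro on this aromatic carbon, ortho to a large group and meta to a large group, gives in this assay a step of a number 3.9 percentage points lower from compound 2 to compound 3 (within the scatter). The reading therefore stays high at this position even when a single fluoro gives way to a group of 10 heavy atoms carrying its own aromatic ring, and the two compounds cannot be told apart here. No measurement available here offers a reason for this result.

With all of these readings near the top of the scale at one concentration, any real difference in potency between the compounds could stay hidden. Going by these compounds, it also remains open whether a much smaller group at this carbon, such as an amine or a carboxylic acid, would keep the reading this high.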